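Compound 1 to compound 3: amide substituent swap

This account rests on a few compounds, and the source may have more. Where it says the series, first, only, none or still open, it means among the compounds named here.

Values so far in an ADME assay on microsomes from liver (Homo sapiens) for metabolic stability (a higher number here means that the compound lasts longer, a lower number that the compound disappears faster), are these:
- compound 1 (`Cc1cccc(NC(=O)c2nn(C)c(-c3ccc(F)cc3)c2C)n1`) gives 1.37 h
- compound 2 (`Cc1cccc(NC(=O)c2nn(C)c(-c3ccc(C(F)(F)F)cc3)c2C)n1`) gives > 5 h as a limit of the assay

Among the measured compounds shown here, compound 1 holds the only actual number, since the reading for compound 2 is a limit. Compound 3 (`Cc1c(C(=O)Nc2ccc(Cl)cn2)nn(C)c1-c1ccc(F)cc1`) keeps the core of compound 1 and carries 5-chloropyridin-2-yl in place of 6-methylpyridin-2-yl on an amide-type nitrogen. For the measured compounds named here, the one measured step (an at least 3.6-fold higher number from compound 1 to compound 2 (0.56 log units; beyond the scatter)) is a different change, trifluoromethyl in place of fluoro on an aromatic carbon, so it bears only loosely here. Going by the values given here, it shows that a single change can move this assay beyond the scatter, but no measured step covers the amide-type nitrogen. A small upward step is therefore expected, not clearly beyond the scatter. The estimated step runs a 1.3-fold higher number from compound 1 to compound 3 (0.12 log units; within the scatter) as a working expectation. Compound 3 is estimated at 1.8 h with an expected range of 0.7 h to 4.5 h for now.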

Compound 3, half-life: > 5 h
Compound 3: no number, only a limit (the forecaster's own chance of this, stated with the estimate: 10%); middle value at least 2.7-fold (0.44 log units) away from the limit.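

In this assay, the amide-type nitrogen is now shown to be a place where one change reaches beyond the scatter: 5-chloropyridin-2-yl in place of 6-methylpyridin-2-yl gives an at least 3.6-fold higher number from compound 1 to compound 3 (0.56 log units; beyond the scatter). Among the compounds shown here, earlier, the only step read was at the aromatic carbon carrying fluoro, an at least 3.6-fold higher number from compound 1 to compound 2 (0.56 log units; beyond the scatter), and the series now has two separate places that each move this read-out. For compound 3, > 5 h is a limit of the assay and not a number, so the full size of its step stays unknown: the limit of > 5 h in this assay, at which 2 of the 3 values shown sit.

The compounds shown do not separate the loss of the methyl from the gain of the chlorine. Also open, as far as these compounds go, is how this assay would read with an amine or a carboxylic acid in place of that chlorine.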